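Swapping thiazole for furan on a conjugated ester chain

The source may report more compounds than this note shows. Statements on the series, on what has been measured and on what is new or still open speak of the compounds shown alone.

Measured in a functional assay on Raji cells (Homo sapiens) for cytotoxicity, with a stated time of 72 h; a higher number here means a weaker inhibitor, a lower number a stronger inhibitor:
Compound 1 `CCOC(=O)/C=C/C=C/C=C/C=C/c1ccc[nH]1`: 4090 nM
Compound 2 `CCOC(=O)/C=C/C=C/C=C/C=C/c1nccs1`: > 10000 nM (a limit of the assay)
Compound 3 `CCOC(=O)/C=C/C=C/C=C/C=C/c1ccco1`: not yet measured

In this assay compound 2 gives > 10000 nM, which is a limit of the assay and not a number. This places it at the limit of > 10000 nM in this assay, at which 1 of the 2 values shown sits.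

The change to compound 3 is furan-2-yl in place of 1,3-thiazol-2-yl on a double-bonded chain carbon bound to a double-bonded chain carbon. Furan-2-yl takes the place of 1,3-thiazol-2-yl on a double-bonded chain carbon bound to a double-bonded chain carbon.

For the measured compounds named here, only one measured step bears on this change: an at least 2.4-fold higher number from compound 1 to compound 2 (0.38 log units; beyond the scatter). There, 1,3-thiazol-2-yl replaced 1H-pyrrol-2-yl at the same place, and the step lies beyond the scatter. Since it ends at a limit, its true size is open. It offers only a rough guide for a third five-membered aromatic ring.

In this assay a modest step to a lower number is expected, and compound 3 may still fall at the limit. The estimated move is an at least 1.4-fold lower number from compound 2 to compound 3 (0.15 log units; that floor lies within the scatter). For compound 3 the estimate is 7000 nM, with an expected range from 3000 nM to 15000 nM.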

Compound 3, half-maximal inhibitory concentration: > 10000 nM
Compound 3: no number, only a limit (the forecaster's own chance of this, stated with the estimate: 40%); middle value at least 1.4-fold (0.15 log units) away from the limit.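

In this assay compound 3 gives > 10000 nM, which is a limit of the assay and not a number, and this limit now holds for most of the series: the limit of > 10000 nM in this assay, at which 2 of the 3 values shown sit.

Furan-2-yl in place of 1H-pyrrol-2-yl on a double-bonded chain carbon bound to a double-bonded chain carbon gives an at least 2.4-fold higher number from compound 1 to compound 3 (0.38 log units; beyond the scatter), so the loss seen earlier with 1,3-thiazol-2-yl is not confined to that one ring and recurs with a second replacement at the same place. The step between the 1,3-thiazol-2-yl and furan-2-yl compounds cannot be read, as both values are limits, and so this change shows no difference and no equivalence between these two rings.

As far as these compounds go, how far compound 2 and compound 3 lie past the limit, and in what order, remains open. Also open, from the compounds shown here alone, is whether any other group at this place, such as a phenyl ring or an amine, would match or improve on the 1H-pyrrol-2-yl ring of compound 1.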